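The source may report more compounds than this note shows. Statements on the series, on what has been measured and on what is new or still open speak of the compounds shown alone.

Measured so far:
Compound 1 `COC(=O)c1ccc(NCc2cncn2Cc2cccc([N+](=O)[O-])c2)cc1-c1ccccc1` — > 10000 nM in a toxicity assay on NIH3T3 cells (Mus musculus) for cytotoxicity, read by resazurin assay (a lower number here means that less compound is needed, a higher number that more compound is needed for the effect), a limit of the assay rather than a number.
Compound 2 `O=C(c1ccc(NCc2cncn2Cc2ccc(-c3ccccc3)cc2)cc1-c1ccccc1)N1CCCCC1` — > 1000 nM in this assay, again a limit.
Compound 3 `Clc1ccc(Cn2cncc2CNc2ccc(-c3nc4ccccc4s3)c(-c3ccccc3)c2)cc1` — > 1000 nM in this assay, again a limit.

Compound 1 stands only at the limit of > 10000 nM in this assay, at which 1 of the 3 values shown sits. Compound 2 and compound 3 stand at the limit of > 1000 nM in this assay, at which 2 of the 3 values shown sit. Within the data shown here, no numbered value exists, so no step between measured compounds can be sized.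

Compound 4 `COC(=O)c1ccc(NCc2cncn2Cc2cccc(Cl)c2)cc1-c1ccccc1` differs from compound 1 by chloro in place of nitro on an aromatic carbon. Among the measured compounds shown here, with no measured step to lean on, no shift beyond the usual scatter is expected in this assay; the likeliest outcome is that compound 4 also returns a limit. Compound 4 is estimated at 10000 nM, with a range from 3000 nM to 30000 nM, which corresponds to an expected step of a number no higher from compound 1 to compound 4 (the limit leaves the size open).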

Compound 4, half-maximal effective concentration: > 10000 nM
Compound 4: only a limit was reported (the forecaster's own chance of this, stated with the estimate: 80%); the middle value sits exactly at the limit.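

Compound 1 and compound 4 both stand at a limit in this assay, and the step between them cannot be read. The compounds shown leave open whether chloro and nitro differ here, and what concentration any compound in the series requires for the effect.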